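The source may hold more compounds than are shown below. What is called first, only, known or untested is meant among the compounds shown, and "the series" means these compounds.

Among the measured compounds shown here, compound 1 `COc1ccc(/C=N/Nc2nc(N)c3ncn([C@@H]4O[C@H](CO)[C@@H](O)[C@H]4O)c3n2)cn1` is the only compound here with a measured number: in an assay on CHO-K1 cells for displacement of a labelled ligand from adenosine receptor A1 (Homo sapiens), read by scintillation counting, with a stated time of 60 min (a lower number here means a stronger inhibitor, a higher number a weaker inhibitor), compound 1 gives 2.6 nM. Compound 2 `Nc1nc(N/N=C/c2ccc(N(c3ccccc3)c3ccccc3)cc2)nc2c1ncn2[C@@H]1O[C@H](CO)[C@@H](O)[C@H]1O` is reported only as a limit of this assay and not as a number, and in this assay compound 2 gives > 10000 nM; this is the limit of > 10000 nM in this assay, at which 1 of the 2 values shown sits. For the measured compounds named here, the two compounds are not joined by a step of a single change, so together they show only that one compound bearing the shared core is a strong inhibitor while the other reaches no measurable number. Compound 3 `CCCCc1nc(/C=N/Nc2nc(N)c3ncn([C@@H]4O[C@H](CO)[C@@H](O)[C@H]4O)c3n2)c(Cl)[nH]1` has not been measured yet. It differs from compound 1 as follows: 2-butyl-5-chloro-1H-imidazol-4-yl in place of 6-methoxypyridin-3-yl on a carbon with a double bond to nitrogen. Going by the values given here, no measured single-change step exists here, so the expectation rests on compound 1 alone. Compound 3 is expected to be somewhat weaker in this assay, with a step of a 12-fold higher number from compound 1 to compound 3 (1.06 log units; beyond the scatter) beyond the usual scatter. The estimate for compound 3 in this assay is 30 nM, with a range from 5 nM to 300 nM.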

Compound 3, inhibition constant: 12 nM
Compound 3: the middle estimate sits 2.5-fold (0.40 log units) above what was measured, within the range that was stated.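

In this assay, among the compounds shown here, the exchange of 6-methoxypyridin-3-yl for 2-butyl-5-chloro-1H-imidazol-4-yl gives a 4.6-fold higher number from compound 1 to compound 3 (0.66 log units; beyond the scatter), the first single change that can be read at this carbon with a double bond to nitrogen. The step is modest, and it shows that a six-membered aromatic ring is not required there for a strong result, since compound 3, with a five-membered aromatic ring carrying a butyl chain and a chlorine, still gives 12 nM. Nothing measured here accounts for the size of this step.

The compounds shown do not separate the share of the butyl chain from that of the chlorine in this step. As far as these compounds go, it remains open whether a propyl chain in place of butyl, or a hydrogen or a methyl group in place of chlorine, would move the number in either direction.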